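A Third Amide at the Cytotoxicity Limit

This account rests on a few compounds, and the source may have more. Where it says the series, first, only, none or still open, it means among the compounds named here.

In an ADME assay on LLC-MK2 cells (Macaca mulatta) for cytotoxicity, read by spectrophotometry and crystal violet staining, with a stated time of 4 days (on this read-out lower numbers stand for higher toxicity in this test and higher numbers for lower toxicity in this test), compound 1 `CC(C)n1ncc2c(C(=O)Nc3ccc(F)cc3)cc(-c3cccs3)nc21` gives > 200000 nM, which is a limit of the assay. Compound 2 `CC(C)n1ncc2c(C(=O)Nc3cccc(F)c3)cc(-c3cccs3)nc21` gives > 200000 nM, also a limit and not a number. Among the measured compounds shown here, the one measured step, a step that the two limits leave unreadable from compound 1 to compound 2, has no readable size. For the measured compounds named here, the only guide is the limit of > 200000 nM in this assay, at which 2 of the 2 values shown sit. Compound 3 `CC(C)n1ncc2c(C(=O)N3CCc4cccnc43)cc(-c3cccs3)nc21` changes the group on a carbonyl carbon: a group of 9 heavy atoms (7 carbon, 2 nitrogen; one five-membered non-aromatic ring with 1 hetero atom, one six-membered aromatic ring with 1 hetero atom) in place of a group of 8 heavy atoms (6 carbon, 1 nitrogen, 1 fluorine; one six-membered aromatic ring of carbon only), on a carbonyl carbon. Going by the values given here, the expected step of a number no higher from compound 2 to compound 3 (the limit leaves the size open) is small, and no measured step sets a direction for it in this assay. For compound 3 the estimated concentration is 200000 nM, with an expected range of 70000 nM to 400000 nM.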

Compound 3, half-maximal cytotoxic concentration: 50000 nM
The estimate for compound 3 lay 4.0-fold (0.60 log units) above the measured number; the measured number lies below the stated range.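

In this assay compound 3 is the first shown to give a number rather than a limit, so this place on a carbonyl carbon can move the read-out: the limit of > 200000 nM in this assay, at which 2 of the 3 values shown sit. The new group comes with an at least 4.0-fold lower number from compound 2 to compound 3 (0.60 log units; beyond the scatter) and with an at least 4.0-fold lower number from compound 1 to compound 3 (0.60 log units; beyond the scatter), so higher toxicity in this test follows a change in this one place. Both sizes are only lower bounds.

Which part of the new group goes with this step stays open. A piperidine amide, or a methyl group on the amide nitrogen of the fluorophenyl amides, could separate the two.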